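A few compounds are considered here, and "the series" means these few. Any claim that something is new, unique, unknown or untested is made for them only; others in the source may bear on it.

Compound 1 `C[N+](C)(C)CCCOc1c(-c2ccc(O)c(O)c2)oc2ccccc2c1=O` and compound 2 `C[N+](C)(C)CCCCCCOc1c(-c2ccc(O)c(O)c2)oc2ccccc2c1=O` share one core and differ only in the length of the chain that ends in the nitrogen group. In a functional assay for inhibition, with Rattus norvegicus as the target, using microsomes (a lower number here means a stronger inhibitor, a higher number a weaker inhibitor), compound 1 gives 1200 nM, and compound 2 gives 1400 nM. Among these two numbers compound 2 holds the higher one, although its gap to compound 1 is within the scatter. The step of a 1.2-fold higher number from compound 1 to compound 2 (0.07 log units; within the scatter) shows that lengthening this chain left the result essentially unchanged. Compound 3 `C[N+](C)(C)CCCCCCCCOc1c(-c2ccc(O)c(O)c2)oc2ccccc2c1=O` keeps the same core and lengthens the chain once more: a group of 6 heavy atoms (5 carbon, 1 nitrogen; no ring) in place of a group of 4 heavy atoms (3 carbon, 1 nitrogen; no ring), on a saturated chain carbon, six bonds along the chain from an oxygen on an aromatic ring. Within the data shown here, the only measured step that bears on this change is the one from compound 1 to compound 2, and it was small. The change from compound 2 to compound 3 is therefore expected to be a 1.1-fold higher number from compound 2 to compound 3 (0.03 log units; within the scatter), with no shift beyond the scatter. Compound 3 is estimated to give 1500 nM, within a range from 700 nM to 3200 nM.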

Compound 3, half-maximal inhibitory concentration: 1000 nM
Beside the measured number, compound 3's estimate is 1.5-fold (0.18 log units) above it; the measured number falls inside the stated range.
By their numbers in this assay, from the lowest: compounds 3, 1 and 2 (each within the scatter of the next).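

The step of a 1.4-fold lower number from compound 2 to compound 3 (0.15 log units; within the scatter) and the step of a 1.2-fold lower number from compound 1 to compound 3 (0.08 log units; within the scatter) both lie within the scatter, so in this assay the third chain length stays level with the other two. Until now only one lengthening could be read; now the shortest and longest chains of the three can also be compared directly, and across this span compound 1, compound 2 and compound 3 do not separate. Nothing available here accounts for this flat result.

Still open, as far as these compounds go, is whether a chain shorter than that of compound 1, or a longer chain than that of compound 3, would stay level too. Also open, from the compounds shown here alone, is whether a tertiary amine or a carboxylic acid at the chain end would give a similar number on the same core.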